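The compounds below may be only part of what the source reports. "The series", "measured", "known", "first", "only" and "open" are said of these compounds alone.

Going by the values given here, in an ADME assay on MT4 cells (Homo sapiens) for cytotoxicity, read by MTT assay, with a stated time of 96 h (on this read-out higher numbers stand for lower toxicity in this test and lower numbers for higher toxicity in this test), three compounds have numbers so far. Compound 1 `C/C(=N\NC(N)=S)c1ccc2[nH]c(-c3ccc(C(F)(F)F)cc3)nc2c1` gives 2000 nM, compound 2 `C/C(=N\NC(N)=S)c1ccc2c(c1)nc(-c1ccccc1)n2C1CCCCC1` gives 20000 nM and compound 3 `C/C(=N\NC(N)=S)c1ccc2c(c1)nc(-c1ccc(Cl)cc1)n2C1CCCCC1` gives 17000 nM. Compound 3 thus stands level with compound 2 within the scatter, and both numbers lie well above that of compound 1. The next step leads to compound 4 `C/C(=N\NC(N)=S)c1ccc2c(c1)nc(-c1ccc(C(F)(F)F)cc1)n2C1CCCCC1`, with the difference trifluoromethyl in place of chloro on an aromatic carbon, para to a large group. Among the compounds with values here, the one measured step at this place is a 1.2-fold lower number from compound 2 to compound 3 (0.07 log units; within the scatter), and it stays within the scatter. Compound 1 also carries 4-(trifluoromethyl)phenyl, but it differs from compound 4 elsewhere on the shared core, so its number says little about this swap. Within the data shown here, with only that single small step as a guide, no change beyond the scatter is expected in this assay. The estimated step is a 1.1-fold lower number from compound 3 to compound 4 (0.05 log units; within the scatter), which lies within the scatter. Compound 4 is expected at 15000 nM, with an estimated range of 7000 nM to 30000 nM.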

Compound 4, half-maximal cytotoxic concentration: 30000 nM
Compound 4: the middle estimate sits 2.0-fold (0.30 log units) below what was measured; the range from low to high includes it.
By their numbers in this assay, from the lowest: compound 1; then compounds 3, 2 and 4 (each within the scatter of the next).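

In this assay, the place para to a large group now carries hydrogen, chloro or trifluoromethyl, and swapping among them leaves the numbers within the scatter: a 1.8-fold higher number from compound 3 to compound 4 (0.25 log units; within the scatter) and a 1.5-fold higher number from compound 2 to compound 4 (0.18 log units; within the scatter) are both printed as such. With 4-(trifluoromethyl)phenyl held constant, the step beyond the scatter appears at the other place, as a 15-fold higher number from compound 1 to compound 4 (1.18 log units; beyond the scatter) comes with cyclohexyl in place of hydrogen on an aromatic nitrogen. Among these four compounds, the large difference therefore goes with the nitrogen substituent and not with the group on the aromatic carbon, but no measurement here offers an explanation for it.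

That reading rests on a single pair, compound 1 and compound 4. From the compounds shown here alone, it remains open where a methyl on that nitrogen would fall, and what an amine or a carboxylic acid on the aromatic carbon would give.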